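The source may report more compounds than this note shows. Statements on the series, on what has been measured and on what is new or still open speak of the compounds shown alone.

Measured compounds:
compound 1 `Oc1cc(C(F)(F)F)ccc1-c1nc(-c2ccccc2O)n(-c2ccc(Br)cc2)n1` — 89.8%
compound 2 `Oc1cc(C(F)(F)F)ccc1-c1nc(-c2ccccc2O)n(-c2ccc(C(F)(F)F)cc2)n1` — 90.5%

Both numbers come from a functional assay on PC-12 cells (Rattus norvegicus) for cytotoxicity, read by MTT assay, with stated times of 2 h and 24 h, tested at 5 uM; on this read-out lower numbers stand for a weaker effect and higher numbers for a stronger effect at the one concentration tested. Compound 2 and compound 1 lie within the scatter of each other, so neither stands apart; both numbers are high on this read-out. The single shown step is a number 0.7 percentage points higher from compound 1 to compound 2 (within the scatter), a change on the group that sits on an aromatic nitrogen of the shared core, and it stayed within the scatter.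

Compound 3 `COc1cccc(-n2nc(-c3ccc(C(F)(F)F)cc3O)nc2-c2ccccc2O)c1` is not yet measured. It differs from compound 2 by 3-methoxyphenyl in place of 4-(trifluoromethyl)phenyl on an aromatic nitrogen. This touches the same group on the aromatic nitrogen as the step from compound 1 to compound 2, but it is a larger change, so that step bears on it only loosely. Within the data shown here, with the step of a number 0.7 percentage points higher from compound 1 to compound 2 (within the scatter) as the only guide, no step beyond the scatter is expected, but the range is set wider. The expected step is a number 5.5 percentage points lower from compound 2 to compound 3 (within the scatter). Compound 3 is expected to give 85%, between 65% and 95%.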

Compound 3, a percentage reported as activity, at one concentration (the size of the read-out at that concentration, not a potency): 96.8%
Compound 3: middle estimate off by 11.8 percentage points, on the low side; the whole stated range lies below it.
By their numbers in this assay, from the lowest: compounds 1, 2 and 3 (each within the scatter of the next).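

In this assay, the aromatic nitrogen accepts 3-methoxyphenyl as readily as either earlier aryl group: the change gives a number 6.3 percentage points higher from compound 2 to compound 3 (within the scatter) and a number 7 percentage points higher from compound 1 to compound 3 (within the scatter). The earlier pair showed only an exchange of one 4-substituted phenyl group for another, whereas this change replaces the halogen-bearing groups with an oxygen-bearing group at a different ring position, and the read-out still stays within the scatter across all three compounds. No supporting measurement is available to explain this result.

The compounds shown leave open whether any group on this nitrogen can move the read-out beyond the scatter, for example a carboxylic acid on the phenyl ring or a longer alkyl chain in its place. They also leave open what the 2-hydroxyphenyl group contributes, since it is common to all three compounds.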